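Working notes: ethyl in place of cyclopentyl

This account rests on a few compounds, and the source may have more. Where it says the series, first, only, none or still open, it means among the compounds named here.

Measured in a functional assay on HL-60 cells (Homo sapiens) for inhibition, read by MTT assay, with a stated time of 72 h; a lower number here means a stronger inhibitor, a higher number a weaker inhibitor:
- compound 1 `CCCO[C@@H]1C=CC(=O)[C@@H](CO)O1`: 10700 nM
- compound 2 `O=C1C=C[C@@H](OC2CCCC2)O[C@@H]1CO`: 4200 nM

For the measured compounds named here, compound 2 holds the lower of the two numbers at 4200 nM, and compound 1 is the only neighbour at 10700 nM. Compound 3 `CCO[C@@H]1C=CC(=O)[C@@H](CO)O1` has not yet been measured. It carries ethyl in place of cyclopentyl on an oxygen on a saturated carbon.

Going by the values given here, one measured step bears on this change: a 2.5-fold lower number from compound 1 to compound 2 (0.41 log units; beyond the scatter), with cyclopentyl in place of propyl at the same place. That step is modest but beyond the scatter. Ethyl has no ring, like the propyl of compound 1, so the change to compound 3 runs against the direction of a 2.5-fold lower number from compound 1 to compound 2 (0.41 log units; beyond the scatter). A higher number in this assay is therefore expected, by about the size of that step or a little more. Among the compounds with values here, a single step supports this, and no ethyl and propyl pair has been measured, so the size remains uncertain.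

The estimate for compound 3 is 12000 nM, with an expected range of 6000 nM to 25000 nM. The expected change is a 2.9-fold higher number from compound 2 to compound 3 (0.46 log units; beyond the scatter).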

Compound 3, half-maximal inhibitory concentration: 3500 nM
Compound 3: the middle estimate sits 3.4-fold (0.54 log units) above what was measured; the measured number lies below the stated range.
By their numbers in this assay, from the lowest: compounds 3 and 2 (each within the scatter of the next); then compound 1.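

In this assay, a ring on the oxygen on a saturated carbon does not separate the compounds: the change shows a 1.2-fold lower number from compound 2 to compound 3 (0.08 log units; within the scatter), so ethyl, with no ring, and cyclopentyl read alike at this place. For the compounds shown here, the single chain change at the same place, from propyl to ethyl, gives a 3.1-fold lower number from compound 1 to compound 3 (0.49 log units; beyond the scatter), which shows that this position responds to a small alteration of an open chain, and that the numbers here do not follow group size, with compound 1 going against any such order as the one that stands apart from both others. No supporting data are available to account for the position of compound 1 or for the likeness of compound 2 and compound 3.

On these data alone, it stays open whether propyl is an isolated case or part of a wider dependence on chain length, which a methyl, a butyl or a longer chain on this oxygen would help to settle. Also open, as far as these compounds go, is how a phenyl or benzyl group, or a chain bearing an amine or a carboxylic acid, would read at this place.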